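Dropping the phenyl on the dimethylamino core

The source may report more compounds than this note shows. Statements on the series, on what has been measured and on what is new or still open speak of the compounds shown alone.

Compound 1 `O=C(CC1c2ccccc2N=C(SCCCCCN2CCCC2)N1c1ccc(-c2ccccc2)cc1)NCc1ccc(F)cc1` gives 19800 nM in a functional assay on A549 cells (Homo sapiens) for cytotoxicity, read by MTT assay, with a stated time of 48 h; on this read-out higher numbers stand for weaker inhibition and lower numbers for stronger inhibition. Compound 2 `O=C(CC1c2ccccc2N=C(SCCCCCN2CCCC2)N1c1ccccc1)NCc1ccc(F)cc1` gives 89900 nM in this assay; the change is hydrogen in place of phenyl on an aromatic carbon and the step is a 4.5-fold higher number from compound 1 to compound 2 (0.66 log units; beyond the scatter). Compound 3 `CN(C)CCCCCSC1=Nc2ccccc2C(CC(=O)NCc2ccc(F)cc2)N1c1ccc(-c2ccccc2)cc1` differs from compound 1 by dimethylamino in place of pyrrolidin-1-yl on a saturated chain carbon, five bonds along the chain from a sulfur; in this assay compound 3 gives 5000 nM, a step of a 4.0-fold lower number from compound 1 to compound 3 (0.60 log units; beyond the scatter); among the three measured compounds its number is the lowest. Compound 4 `CN(C)CCCCCSC1=Nc2ccccc2C(CC(=O)NCc2ccc(F)cc2)N1c1ccccc1` has not yet been measured; it differs from compound 3 by hydrogen in place of phenyl on an aromatic carbon, the same change at a place described in the same words as before. The step expected is a 4.4-fold higher number from compound 3 to compound 4 (0.64 log units; beyond the scatter), resting on the earlier pair, because a 4.5-fold higher number from compound 1 to compound 2 (0.66 log units; beyond the scatter) was seen on the other core. Compound 4 is therefore estimated to give 22000 nM in this assay, between 10000 nM and 50000 nM.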

Compound 4, half-maximal inhibitory concentration: 36800 nM
The estimate for compound 4 lay 1.7-fold (0.22 log units) below the measured number; low and high end bracket the measured number.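

Removing the outer phenyl from the 4-phenylphenyl group on the core of compound 3 gives a 7.4-fold higher number from compound 3 to compound 4 (0.87 log units; beyond the scatter), so in this assay this change carries over from the core of compound 1 in direction and in size: the same change on two cores in this assay, a 4.5-fold higher number (0.66 log units; beyond the scatter) from compound 1 to compound 2 and a 7.4-fold higher number (0.87 log units; beyond the scatter) from compound 3 to compound 4, 1.6-fold (0.21 log units) apart, within the scatter of two such steps. Dimethylamino in place of pyrrolidin-1-yl also carries over, now on the core of compound 2, with a 2.4-fold lower number from compound 2 to compound 4 (0.39 log units; beyond the scatter): the same change on two cores in this assay, a 4.0-fold lower number (0.60 log units; beyond the scatter) from compound 1 to compound 3 and a 2.4-fold lower number (0.39 log units; beyond the scatter) from compound 2 to compound 4, 1.6-fold (0.21 log units) apart, within the scatter of two such steps. These four compounds show the two changes acting consistently on each other's cores, but they do not show why, nor that this holds beyond this set.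

Going by these compounds, whether a piperidine or morpholine would follow the dimethylamino or the pyrrolidin-1-yl compounds remains open. So does the effect of a chlorine or methoxy group in place of the outer phenyl.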